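The source may hold more compounds than are shown below. What is called first, only, known or untested is meant among the compounds shown, and "the series" means these compounds.

Measured so far in a physicochemical assay for lipophilicity; a lower number here means a more polar compound, a higher number a more lipophilic compound:
Compound 1, `CCCCCOc1ccc2[nH]c(-c3ccc(OC)cc3)c(C3=C(Br)C(=O)NC3=O)c2c1`: compound 1 gives 3.77.
Compound 2, `CCCCCCOc1ccc2[nH]c(-c3ccc(OC)cc3)c(C3=C(Br)C(=O)NC3=O)c2c1`: compound 2 gives 4.1.
Compound 3, `CCCCCc1ccc2[nH]c(-c3ccccc3)c(C3=C(Br)C(=O)NC3=O)c2c1`: compound 3 gives 4.07.

Compound 4, `CCCCCCc1ccc2[nH]c(-c3ccccc3)c(C3=C(Br)C(=O)NC3=O)c2c1`, has not yet been measured in this assay.

Compound 2 differs from compound 1 by methyl in place of hydrogen on a saturated chain carbon, five bonds along the chain from an oxygen on an aromatic ring. That change made a number 0.33 log units higher from compound 1 to compound 2 (beyond the scatter). Compound 4 differs from compound 3 by methyl in place of hydrogen on a saturated chain carbon, five bonds along the chain from an aromatic carbon. The surroundings of the place are not identical: in the first pair the chain is counted from an oxygen on an aromatic ring, in the second from an aromatic carbon, so this is the same kind of change rather than the same change. The difference between the core of compound 1 and the core of compound 3 is not broken down here. The values of compound 3 and compound 2 lie within the scatter of each other, as do the values of compound 3 and compound 1.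

Within the data shown here, on this basis a step of similar size is expected in this assay; the expectation rests on a number 0.33 log units higher from compound 1 to compound 2 (beyond the scatter) as the only measured instance of this kind of change. The expected step is a number 0.33 log units higher from compound 3 to compound 4 (beyond the scatter). For compound 4 a value of about 4.4 is estimated, with a likely range from 4.15 to 4.65.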

Compound 4, partition coefficient: 4.39
Compound 4: middle estimate off by 0.01 log units, on the high side, within the range that was stated.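

In this assay the methyl in place of hydrogen gives a number 0.32 log units higher from compound 3 to compound 4 (beyond the scatter) and the same kind of change counted from an oxygen on an aromatic ring gives a number 0.33 log units higher from compound 1 to compound 2 (beyond the scatter), so across these two pairs the step carries from one core to the other with its direction kept and its size close. This rests on two pairs at a single place on the chain: it sets no rule for other cores or other chain places, and it does not break down the difference between the core of compound 1 and the core of compound 3. Nothing available here bears on why the step has this size.

The compounds shown leave open whether a longer chain on either core would add a further step of similar size. Also open, as far as these compounds go, is whether the step holds when the chain carries an amine or a carboxylic acid.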